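Methoxy-to-bromo step on a second core

This account rests on a few compounds, and the source may have more. Where it says the series, first, only, none or still open, it means among the compounds named here.

Measured compounds:
- compound 1, `CCOC(=O)c1csc2nc(CN3CCN(Cc4ccccc4)CC3)c(-c3ccc(OC)cc3)n12`: 9940 nM
- compound 2, `CCOC(=O)c1csc2nc(CN3CCN(Cc4ccccc4)CC3)c(-c3ccc(Br)cc3)n12`: 29500 nM
- compound 3, `COc1ccc(-c2cnc3scc(C(=O)NNC(C)=O)n23)cc1`: 17900 nM

All three were tested in a functional assay on HeLa cells (Homo sapiens) for antiproliferative activity, read by MTT assay, with a stated time of 72 h; on this read-out lower numbers stand for stronger inhibition and higher numbers for weaker inhibition. Compound 1 and compound 2 share one core; compound 3 carries a different core, and the difference between the two cores is not broken down here. Within the first pair the change bromo in place of methoxy on an aromatic carbon gave a 3.0-fold higher number from compound 1 to compound 2 (0.47 log units; beyond the scatter).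

Compound 4, `CC(=O)NNC(=O)c1csc2ncc(-c3ccc(Br)cc3)n12`, is not yet measured. It differs from compound 3 by bromo in place of methoxy on an aromatic carbon, the same change as from compound 1 to compound 2, made at the same kind of place. Because compound 1 to compound 2 gave a 3.0-fold higher number from compound 1 to compound 2 (0.47 log units; beyond the scatter), a step of similar direction and size is expected, as a 2.5-fold higher number from compound 3 to compound 4 (0.40 log units; beyond the scatter). As far as these compounds go, whether the second core carries the change in the same way is untested, so the range is kept wide. Compound 4 is estimated at 45000 nM in this assay, between 18000 nM and 110000 nM.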

Compound 4, half-maximal inhibitory concentration: 4780 nM
For compound 4 the middle estimate is 9.4-fold (0.97 log units) above the measured one; measured number below the stated range.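

In this assay the change of bromo in place of methoxy on an aromatic carbon gives a 3.7-fold lower number from compound 3 to compound 4 (0.57 log units; beyond the scatter) on the core of compound 3, so its direction does not carry over from the core of compound 1: the same change on two cores in this assay, a 3.0-fold higher number (0.47 log units; beyond the scatter) from compound 1 to compound 2 and a 3.7-fold lower number (0.57 log units; beyond the scatter) from compound 3 to compound 4, 11-fold (1.05 log units) apart, beyond the scatter of two such steps.
A step measured on one of these cores therefore does not predict the step on the other for this pair of groups.
This rests on two pairs only and gives no general rule, nor does it show which of the differences between the two cores reverses the step.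

Open, as far as these compounds go, is how chloro or fluoro would read at the same place on each core.
Also open, from the compounds shown here alone, is whether a carboxylic acid in place of the ethyl ester of compound 1 would shift the step towards that seen on the core of compound 3.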